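Replacing the 4-methylpiperazin-1-yl group of compound 2

This account rests on a few compounds, and the source may have more. Where it says the series, first, only, none or still open, it means among the compounds named here.

Compound 1 `CCc1cccc(CC)c1NC(=O)c1cc(-c2nc(Nc3ccc(N4CCC(N5CCN(C)CC5)CC4)cc3OC)nc3[nH]ccc23)n(C)n1`: 17 nM
Compound 2 `CCc1cccc(CC)c1N1CCn2cc(-c3nc(Nc4ccc(N5CCC(N6CCN(C)CC6)CC5)cc4OC)nc4[nH]ccc34)cc2C1=O`: 9 nM

These two values come from a functional assay on CAL-51 cells (Homo sapiens) for inhibition, read by luminescence, with a stated time of 3 days; a higher number here means a weaker inhibitor, a lower number a stronger inhibitor. Compound 2, at 9 nM, stands within the usual scatter of compound 1, at 17 nM, so the two numbers do not rank them.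

Compound 3 `CCc1cccc(CC)c1N1CCn2cc(-c3nc(Nc4ccc(N5CCC(C(=O)N6CC7(CN(C)C7)C6)CC5)cc4OC)nc4[nH]ccc34)cc2C1=O` has not yet been measured. It keeps the rest of compound 2 and differs in one place: a group of 10 heavy atoms (7 carbon, 2 nitrogen, 1 oxygen; 2 four-membered non-aromatic rings with 1 hetero atom each) in place of a group of 7 heavy atoms (5 carbon, 2 nitrogen; one six-membered non-aromatic ring with 2 hetero atoms), on a saturated ring carbon. The 4-methylpiperazin-1-yl group leaves a saturated ring carbon, and a group with 2 four-membered non-aromatic rings takes its place.

For the measured compounds named here, compound 1 and compound 2 both carry the 4-methylpiperazin-1-yl group, so no measured pair shows what this exchange does. The expectation therefore rests on the structural change alone and remains uncertain. In this assay, only a small weakening, within the scatter, is expected, an estimated 1.7-fold higher number from compound 2 to compound 3 (0.22 log units; within the scatter). For compound 3 the expected value is 15 nM, with an estimated range from 5 nM to 45 nM.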

Compound 3, half-maximal inhibitory concentration: 16 nM
Compound 3: middle estimate off by 1.1-fold (0.03 log units), on the low side; low and high end bracket the measured number.
By their numbers in this assay, from the lowest: compounds 2, 3 and 1 (each within the scatter of the next).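

In this assay, exchanging the 4-methylpiperazin-1-yl group for the group with 2 four-membered non-aromatic rings gives a 1.8-fold higher number from compound 2 to compound 3 (0.25 log units; within the scatter). The saturated ring carbon, three ring bonds from the ring nitrogen, therefore accepts a group of 10 heavy atoms, with 1 double bond outside aromatic rings, in place of one of 7 heavy atoms, and this read-out resolves no change in inhibition. The earlier compounds both carried the 4-methylpiperazin-1-yl group and could not show this, but no measurement bearing on the result is available to account for it.

The compounds shown leave open whether other groups on this carbon, such as a morpholine, a dimethylamino group or a carboxylic acid, would also stay within the scatter of compound 2, so the limits of what this position accepts remain unknown. They also leave open whether the same exchange would have a similarly small effect on compound 1, whose core differs from that of compound 2 and which still carries the 4-methylpiperazin-1-yl group.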